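This account rests on a few compounds, and the source may have more. Where it says the series, first, only, none or still open, it means among the compounds named here.

Compound 3, `CN(C)CCn1cnnc1-c1cc(Oc2ccc(NC(=O)N/N=C/c3c(O)ccc4ccccc34)cc2F)ccn1`, stands lowest among the numbers shown for a functional assay on U-87MG ATCC cells (Homo sapiens) for cytotoxicity, read by MTT assay, with a stated time of 72 h (on this read-out higher numbers stand for weaker inhibition and lower numbers for stronger inhibition), giving 620 nM. Compound 2, `COc1cc(/C=N/NC(=O)Nc2ccc(Oc3ccnc(-c4nncn4CCN(C)C)c3)c(F)c2)cc(OC)c1OC`, gives 22500 nM in this assay, so the step of a 36-fold lower number from compound 2 to compound 3 (1.56 log units; beyond the scatter) is a large one. Compound 1, `CN(C)CCn1cnnc1-c1cc(Oc2ccc(NC(=O)N/N=C/c3c(Cl)cccc3Cl)cc2F)ccn1`, sits only at a limit of this assay, > 100000 nM. Its steps of an at least 160-fold lower number from compound 1 to compound 3 (2.20 log units; beyond the scatter) and an at least 4.4-fold lower number from compound 1 to compound 2 (0.64 log units; beyond the scatter) are accordingly limits as well. Compound 4, `COc1ccc(/C=N/NC(=O)Nc2ccc(Oc3ccnc(-c4nncn4CCN(C)C)c3)c(F)c2)cc1O`, differs from compound 3 in one place: 3-hydroxy-4-methoxyphenyl in place of 2-hydroxynaphthalen-1-yl on a carbon with a double bond to nitrogen. Both measured steps change the ring on that same carbon, and in both the 2-hydroxynaphthalen-1-yl group gives the lower number than a phenyl ring carrying other substituents. A step upward is therefore expected for compound 4, an 8.1-fold higher number from compound 3 to compound 4 (0.91 log units; beyond the scatter), landing at an estimated 5000 nM, with a range from 1500 nM to 20000 nM.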

Compound 4, half-maximal inhibitory concentration: > 100000 nM
Compound 4 gave a limit, no number (the forecaster's own chance of this, stated with the estimate: 5%); middle value at least 20-fold (1.30 log units) from the limit.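

A hydroxy group on the ring at this carbon does not by itself give a low number, since both rings carry one, yet the change brings an at least 160-fold higher number from compound 3 to compound 4 (2.20 log units; beyond the scatter). The phenyl rings also separate from one another, with an at least 4.4-fold higher number from compound 2 to compound 4 (0.64 log units; beyond the scatter). The step from compound 1 to compound 4 cannot be read, and compound 4, like compound 1, gives only a limit: the limit of > 100000 nM in this assay, at which 2 of the 4 values shown sit.

As far as these compounds go, what remains open is whether the gain in compound 3 follows the second aromatic ring or the place of the hydroxy group. A plain naphthalen-1-yl or a 2-hydroxyphenyl group would separate the two.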